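This account rests on a few compounds, and the source may have more. Where it says the series, first, only, none or still open, it means among the compounds named here.

Measured compounds:
- compound 1 `COc1ccc(/C=C/C[C@H]2C[C@H]([C@H](O)c3ccc(OC)c(OC)c3)CO[C@@H]2c2ccc(OC)c(OC)c2)cc1OC` — 23500 nM
- compound 2 `COc1cccc(/C=C/C[C@H]2C[C@@H]([C@@H](O)c3ccccc3)CO[C@@H]2c2ccccc2)c1` — 9620 nM
- compound 3 `COc1ccc(/C=C/C[C@@H]2C[C@H]([C@H](O)c3ccc(OC)c(OC)c3)CO[C@H]2c2ccc(OC)c(OC)c2)cc1OC` — "not determined" (no result reported)

In a functional assay on HL-60 cells (Homo sapiens) for cytotoxicity, read by WST assay, with a stated time of 48 h (on this read-out higher numbers stand for weaker inhibition and lower numbers for stronger inhibition), compound 2 gives 9620 nM, the lower of the two numbers that were obtained. Compound 1 gives 23500 nM, and the gap between these two lies beyond the usual scatter of repeated measurements, so compound 2 is the stronger inhibitor of the pair. Compound 3 is reported as "not determined" (no result reported) in this assay; the fact that compounds 1 and 3 differ only in the configuration as drawn is all that can be said about it.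

Compound 4 `O[C@@H](c1ccccc1)[C@H]1CO[C@H](c2ccccc2)[C@@H](C/C=C/C2CCCCC2)C1` is built from compound 2 by one change:
cyclohexyl in place of 3-methoxyphenyl on a double-bonded chain carbon bound to a double-bonded chain carbon
Among the measured compounds shown here, no measured pair in this set shows a change of this kind, so the expectation rests on compound 2 alone. The step from compound 2 to compound 4 is expected to be a small weakening, a 1.5-fold higher number from compound 2 to compound 4 (0.16 log units; within the scatter), close to the edge of the scatter rather than clearly beyond it. Compound 4 is therefore estimated at 14000 nM in this assay, with a range from 5000 nM to 40000 nM.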

Compound 4, half-maximal inhibitory concentration: 6260 nM
The estimate for compound 4 lay 2.2-fold (0.35 log units) above the measured number; low and high end bracket the measured number.
By their numbers in this assay, from the lowest: compounds 4 and 2 (each within the scatter of the next); then compound 1.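

In this assay, cyclohexyl in place of 3-methoxyphenyl on a double-bonded chain carbon bound to a double-bonded chain carbon gives a 1.5-fold lower number from compound 2 to compound 4 (0.19 log units; within the scatter), so the two numbers cannot be told apart. Among the compounds shown here, in this one pair, then, a non-aromatic carbon ring with no hydrogen-bond acceptor serves as well as an aromatic ring bearing a methoxy group, which no earlier compound could show. Nothing on hand accounts for how closely the two numbers agree.

On these data alone, how a longer chain, an amine or a carboxylic acid would read at this place stays open, and so does whether any ring is needed there at all. Also open, as far as these compounds go, is whether the same swap would read alike on the core of compound 1, which gives 23500 nM.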